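Swapping Ethyl for Chlorophenyl on the Shared Core

A few compounds are considered here, and "the series" means these few. Any claim that something is new, unique, unknown or untested is made for them only; others in the source may bear on it.

Of the compounds shown here, three built on the same fused core have been tested in an assay on HepG2 cells for agonist activity at nuclear receptor subfamily 1 group I member 3 (Homo sapiens), read by a luciferase reporter, with a stated time of 23 h; a higher number here means that more compound is needed for the effect, a lower number that less compound is needed. Compound 1 `Clc1ccc(CO/N=C/c2c(-c3ccc(Br)cc3)nc3sccn23)cc1Cl` gives 480 nM. Compound 2 `CC(C)(C)c1ccc(-c2nc3sccn3c2/C=N/OCc2ccc(Cl)c(Cl)c2)cc1` gives 2400 nM. Compound 3 `CCc1nc2sccn2c1/C=N/OCc1ccc(Cl)c(Cl)c1` gives 2600 nM, the highest of the three numbers; it is separated from compound 2 by only a 1.1-fold higher number from compound 2 to compound 3 (0.03 log units; within the scatter), which is within the scatter, while a 5.4-fold higher number from compound 1 to compound 3 (0.73 log units; beyond the scatter) lies beyond it.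

Compound 4 `Clc1cccc(-c2nc3sccn3c2/C=N/OCc2ccc(Cl)c(Cl)c2)c1` has not yet been measured. It differs from compound 3 in one place: 3-chlorophenyl in place of ethyl on an aromatic carbon.

For the measured compounds named here, two measured steps bear on this change, both concerning the same carbon of the core. The step of a 5.4-fold higher number from compound 1 to compound 3 (0.73 log units; beyond the scatter) shows that putting ethyl in place of 4-bromophenyl raised the number by a modest amount, whereas the step of a 1.1-fold higher number from compound 2 to compound 3 (0.03 log units; within the scatter) shows that the same swap from 4-(tert-butyl)phenyl changed nothing beyond the scatter. The entering 3-chlorophenyl carries a halogen, as does the bromophenyl of compound 1, so compound 4 is expected to show a modest drop, roughly a 3.3-fold lower number from compound 3 to compound 4 (0.51 log units; beyond the scatter), in this assay. The outcome for compound 2 at 2400 nM warns that an aromatic ring alone need not help. Compound 4 is therefore estimated at 800 nM, with a range from 300 nM to 2500 nM.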

Compound 4, half-maximal effective concentration: 1100 nM
Estimate against measurement, compound 4: 1.4-fold (0.14 log units) below, within the range that was stated.
By their numbers in this assay, from the lowest: compound 1; then compound 4; then compounds 2 and 3 (each within the scatter of the next).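

Compound 4 shows that an aromatic ring on this carbon of the shared core can lower the number relative to ethyl in this assay, with a 2.4-fold lower number from compound 3 to compound 4 (0.37 log units; beyond the scatter), something the match between compound 2 and compound 3 gave no sign of. The nature of the ring matters as well: 3-chlorophenyl gives a 2.2-fold lower number from compound 2 to compound 4 (0.34 log units; beyond the scatter) when it replaces 4-(tert-butyl)phenyl, but a 2.3-fold higher number from compound 1 to compound 4 (0.36 log units; beyond the scatter) when it replaces 4-bromophenyl, which places this ring between the other two aromatic groups. Nothing available here accounts for this order among the rings.

Since 3-chlorophenyl and 4-bromophenyl differ in both the halogen and where it sits on the ring, the compounds shown cannot separate these two changes, and a 4-chlorophenyl or 3-bromophenyl group would be needed to do so. Also open, going by these compounds, is how an unsubstituted phenyl ring, or a ring carrying an amine or a carboxylic acid, would compare at this carbon, and whether a longer chain such as butyl would differ from ethyl.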